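This account rests on a few compounds, and the source may have more. Where it says the series, first, only, none or still open, it means among the compounds named here.

The measured compounds so far:

Compound 1, `Cc1nn(-c2ccccc2)c2nc(C(=O)N3NC(=O)/C(=C/c4ccccc4)N=C3c3ccccc3)[nH]c(=O)c12`, with 14.7 nM.

Compound 2, `Cc1nn(-c2ccccc2)c2nc(C(=O)N3NC(=O)/C(=C/c4ccccc4)N=C3c3ccc(Cl)cc3)[nH]c(=O)c12`, with 13.9 nM.

In a functional assay on HCT-116 cells (Homo sapiens) for cytotoxicity, read by MTT assay, with a stated time of 48 h (on this read-out higher numbers stand for weaker inhibition and lower numbers for stronger inhibition), compound 2 stands at the lowest of the two numbers, and its nearest neighbour is compound 1; the step of a 1.1-fold lower number from compound 1 to compound 2 (0.02 log units; within the scatter) lies within the scatter, so the two compounds cannot be told apart on this read-out.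

Compound 3, `COc1ccc(/C=C2\N=C(c3ccc(Cl)cc3)N(C(=O)c3nc4c(c(C)nn4-c4ccccc4)c(=O)[nH]3)NC2=O)cc1`, is the next compound in this line. It differs from compound 2 by methoxy in place of hydrogen on an aromatic carbon. For the measured compounds named here, only one measured step is available for comparison, and it concerns a different ring and a different group, namely the chloro substitution that gave a 1.1-fold lower number from compound 1 to compound 2 (0.02 log units; within the scatter). Going by the values given here, that single step was within the scatter, and there is no measured example of a methoxy group at this position, so the data offer no ground for a shift in either direction.

The step from compound 2 to compound 3 is therefore expected to be small, around a 1.1-fold lower number from compound 2 to compound 3 (0.03 log units; within the scatter). On this basis compound 3 is estimated at 13 nM in this assay. The range for compound 3 is expected to run from 5 nM to 35 nM.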

Compound 3, half-maximal inhibitory concentration: 12.9 nM
Estimate against measurement, compound 3: 1.0-fold (0.00 log units) above, and the stated range covers the measured number.
By their numbers in this assay, from the lowest: compounds 3, 2 and 1 (each within the scatter of the next).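

In this assay, for the compounds shown here, the change from phenyl to 4-methoxyphenyl gives a 1.1-fold lower number from compound 2 to compound 3 (0.03 log units; within the scatter) and so shows that this aromatic carbon, para to a large group, accepts methoxy with no step that can be told from the scatter. Taken with a 1.1-fold lower number from compound 1 to compound 2 (0.02 log units; within the scatter) on the other ring, it means that neither of the two single substitutions shown separates its pair of compounds on this read-out, a statement that holds for compounds 1, 2 and 3 only. No supporting measurement bears on why this step is so small.

The compounds shown leave open whether an amine or a carboxylic acid at this same position, or a longer chain such as ethoxy or butoxy in place of methoxy, would give a step beyond the scatter. They also leave open whether methoxy on this ring would give a similar number with hydrogen rather than chloro on the other ring, and whether a group on the core's own phenyl or methyl would matter more than either change seen so far.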